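Compound 1 to compound 3: the methoxy step

The compounds below may be only part of what the source reports. "The series", "measured", "known", "first", "only" and "open" are said of these compounds alone.

Compound 1 `O=C(/C=C\Nc1ccccc1)c1ccc2c(c1)CCCC2`: 19.9 ug/mL
Compound 2 `Cc1ccc(N/C=C\C(=O)c2ccc3c(c2)CCCC3)cc1`: 42.7 ug/mL

Among the compounds with values here, in a functional assay on HepG2 cells (Homo sapiens) for cytotoxicity, read by MTT assay, with a stated time of 48 h (on this read-out higher numbers stand for weaker inhibition and lower numbers for stronger inhibition), compound 1 gives 19.9 ug/mL, the lowest of the two numbers so far. Compound 3 `COc1ccc(N/C=C\C(=O)c2ccc3c(c2)CCCC3)cc1` differs from it by one change: methoxy in place of hydrogen on an aromatic carbon. Within the data shown here, the only measured step that bears on this is another replacement of hydrogen on an aromatic carbon, methyl for compound 2: a 2.1-fold higher number from compound 1 to compound 2 (0.33 log units; beyond the scatter). Among the measured compounds shown here, this modest step is the sole guide, and no methoxy compound has been measured yet. The estimated step is a 1.7-fold higher number from compound 1 to compound 3 (0.22 log units; within the scatter), expected in the same direction and of similar or smaller size. For compound 3 the expected value is 33 ug/mL, with an estimated range of 15 ug/mL to 70 ug/mL.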

Compound 3, half-maximal inhibitory concentration: 31.8 ug/mL
Compound 3: middle estimate off by 1.0-fold (0.02 log units), on the high side; measured number inside the range.
By their numbers in this assay, from the lowest: compounds 1, 3 and 2 (each within the scatter of the next, the first and the last beyond it).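

In this assay, methoxy para to a large group gives a 1.6-fold higher number from compound 1 to compound 3 (0.20 log units; within the scatter), so this change cannot be separated from the scatter, whereas the methyl change gave a 2.1-fold higher number from compound 1 to compound 2 (0.33 log units; beyond the scatter). Exchanging the two groups at this place gives a 1.3-fold lower number from compound 2 to compound 3 (0.13 log units; within the scatter), so methoxy and methyl are not told apart here. No data at hand explain either step.

Still open, from the compounds shown here alone, is how an amine, a carboxylic acid or a chlorine atom would read at this carbon. Also open, going by these compounds, is whether methoxy would read the same on the other carbons of this ring.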